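The source may hold more compounds than are shown below. What is called first, only, known or untested is meant among the compounds shown, and "the series" means these compounds.

Compound 3 `CCCCc1ccc(/C=C/C(=O)Nc2ccc3nc(CCC)cc(N)c3c2)cc1` stands highest among the three measured compounds in a functional assay on HEK293 cells for activation of melanin-concentrating hormone receptor 1 (Homo sapiens), read by inositol phosphate accumulation (on this read-out lower numbers stand for an effect already at smaller amounts and higher numbers for an effect only at larger amounts of compound), with 740 nM; compound 1 `CCCc1cc(N)c2cc(NC(=O)/C=C/c3ccc(CC)cc3)ccc2n1` gives 160 nM and compound 2 `CCCc1cc(N)c2cc(NC(=O)/C=C/c3ccc(Br)cc3)ccc2n1` gives 93 nM. Compound 4 `CCCc1cc(N)c2cc(NC(=O)/C=C/c3ccc(SC)cc3)ccc2n1` differs from compound 3 in one place: methylsulfanyl in place of butyl on an aromatic carbon. Among the compounds with values here, two measured steps bear on this change, since both reach the butyl of compound 3. The step of an 8.0-fold higher number from compound 2 to compound 3 (0.90 log units; beyond the scatter) and the step of a 4.6-fold higher number from compound 1 to compound 3 (0.67 log units; beyond the scatter) were both modest. Removing the butyl in favour of a two-heavy-atom group is therefore expected to reverse part of those steps, so a modestly lower number is expected for compound 4, as a 4.9-fold lower number from compound 3 to compound 4 (0.69 log units; beyond the scatter). Compound 4 is estimated at 150 nM, within a range from 50 nM to 500 nM.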

Compound 4, half-maximal effective concentration: 71 nM
The estimate for compound 4 lay 2.1-fold (0.32 log units) above the measured number; low and high end bracket the measured number.
By their numbers in this assay, from the lowest: compounds 4, 2 and 1 (each within the scatter of the next, the first and the last beyond it); then compound 3.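

Methylsulfanyl in place of butyl gave the largest step at this position in this assay (a 10-fold lower number from compound 3 to compound 4 (1.02 log units; beyond the scatter)), so butyl stands apart from all three other groups. Methylsulfanyl in place of bromo stays within the scatter (a 1.3-fold lower number from compound 2 to compound 4 (0.12 log units; within the scatter)), whereas methylsulfanyl in place of ethyl goes beyond it (a 2.3-fold lower number from compound 1 to compound 4 (0.35 log units; beyond the scatter)). Nothing at hand tells why butyl stands apart. From the compounds shown here alone, it stays open whether a propyl chain, a methoxy or an amine on this aromatic carbon would group with butyl or with the three others.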